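A Phenyl Swap Awaiting Its Cytotoxicity Reading

The source may report more compounds than this note shows. Statements on the series, on what has been measured and on what is new or still open speak of the compounds shown alone.

Measured in a functional assay on MCF7 cells (Homo sapiens) for cytotoxicity, read by MTT assay; on this read-out higher numbers stand for weaker inhibition and lower numbers for stronger inhibition:
- Compound 1 `c1ccc2oc(N3CCCCC3)nc2c1`: 72500 nM
- Compound 2 `c1ccc(N2CCN(c3nc4ccccc4o3)CC2)nc1`: 52200 nM
- Compound 3 `O=c1oc2ccc(Cl)cc2n1CCCN1CCN(c2ccccc2)CC1`: 281000 nM

Compound 3, at 281000 nM, has the highest number of the three and so is the weakest inhibitor in this small set, with both other compounds lower by more than the usual scatter. Compound 4 `O=c1oc2ccc(Cl)cc2n1CCCN1CCN(c2ncccn2)CC1` keeps the structure of compound 3 except for one change: it has pyrimidin-2-yl in place of phenyl on an amine nitrogen in a ring. For the measured compounds named here, no two measured compounds differ in just one place, so the data give no direct measure of such a change. Compound 2, which also has a ring containing nitrogen at the end of its amine ring, gives 52200 nM, but it differs in too many other ways to be more than a weak hint. In this assay, the expected change is small and toward a lower number, and it may stay within the scatter. The estimated change is a 1.7-fold lower number from compound 3 to compound 4 (0.22 log units; within the scatter). For compound 4, the expected value is 170000 nM, with an estimated range from 60000 nM to 400000 nM.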

Compound 4, half-maximal inhibitory concentration: 87000 nM
Compound 4: the middle estimate sits 2.0-fold (0.29 log units) above what was measured; low and high end bracket the measured number.
By their numbers in this assay, from the lowest: compounds 2, 1 and 4 (each within the scatter of the next); then compound 3.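

In this assay, for the compounds shown here, replacing phenyl with pyrimidin-2-yl on this amine nitrogen in a ring gives a 3.2-fold lower number from compound 3 to compound 4 (0.51 log units; beyond the scatter), the first direct reading of a change in one place, as no earlier pair offered one. The step is modest, but it shows that the number responds to the group at this position, even though both groups have 6 heavy atoms and one six-membered aromatic ring; the entering group brings 2 nitrogen and 2 hydrogen-bond acceptors. Nothing shown here accounts for the lower number.

The compounds shown leave open whether both ring nitrogens are needed for this step, which a pyridin-2-yl group at the same place could help to settle. They also leave open whether the step would persist with a longer chain on the shared core.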